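Cytotoxicity of a quinoline series: moving from isobutyl to trifluoromethylbenzyl

The source may report more compounds than this note shows. Statements on the series, on what has been measured and on what is new or still open speak of the compounds shown alone.

Three compounds share one core and differ only in the group on an aromatic carbon. In an ADME assay on HepG2 cells (Homo sapiens) for cytotoxicity, read by luminescence, CellTiter-Glo and ATP content, with a stated time of 72 h (a lower number here means that less compound is needed, a higher number that more compound is needed for the effect), compound 1 `CCC(CC)c1ccc2c(NCCCNCc3cccc(OC)c3O)ccnc2c1` gives 410 nM, compound 2 `COc1cccc(CNCCCNc2ccnc3cc(Oc4cccc(N(C)C)c4)ccc23)c1O` gives 7300 nM, and compound 3 `COc1cccc(CNCCCNc2ccnc3cc(CC(C)C)ccc23)c1O` gives 2920 nM, the second highest of the three numbers. Compound 4 `COc1cccc(CNCCCNc2ccnc3cc(Cc4cccc(C(F)(F)F)c4)ccc23)c1O` is the unmeasured one; its change from compound 3 is 3-(trifluoromethyl)phenyl in place of isopropyl on a saturated chain carbon bound to an aromatic carbon. Going by the values given here, two measured steps bear on this: a 7.1-fold higher number from compound 1 to compound 3 (0.85 log units; beyond the scatter) and a 2.5-fold lower number from compound 2 to compound 3 (0.40 log units; beyond the scatter), both modest, with the aromatic-bearing substituent giving the higher number. An aromatic ring now enters through the benzyl, so a modest rise in this assay is expected, written as a 1.2-fold higher number from compound 3 to compound 4 (0.08 log units; within the scatter). Compound 4 is therefore estimated at 3500 nM, with a range from 1000 nM to 12000 nM.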

Compound 4, half-maximal effective concentration: 1720 nM
Compound 4: middle estimate off by 2.0-fold (0.31 log units), on the high side; low and high end bracket the measured number.
By their numbers in this assay, from the lowest: compound 1; then compounds 4 and 3 (each within the scatter of the next); then compound 2.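

In this assay, 3-(trifluoromethyl)phenyl in place of isopropyl gives a 1.7-fold lower number from compound 3 to compound 4 (0.23 log units; within the scatter), so bringing an aromatic ring onto this saturated chain carbon leaves the number within the scatter. An aromatic ring alone does not set the number, since the step with a 4.2-fold lower number from compound 2 to compound 4 (0.63 log units; beyond the scatter) separates two ring-bearing groups, while a 4.2-fold higher number from compound 1 to compound 4 (0.62 log units; beyond the scatter) leaves the pentan-3-yl of compound 1 with the lowest number of the four. No measurement shown explains these differences.

Open, going by these compounds, is whether the trifluoromethyl matters, as a plain benzyl is absent from this set. Also open, on these data alone, is how an amine or a carboxylic acid in its place would read.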